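This account rests on a few compounds, and the source may have more. Where it says the series, first, only, none or still open, it means among the compounds named here.

Measured so far:
compound 1, `O=c1cc(CNc2nc(-c3cc4cc(Br)cc(Br)c4oc3=O)cs2)c2cc(Cl)ccc2[nH]1`, 6.75%;
compound 2, `Cc1cccc2c(CNc3nc(-c4cc5cc(Br)ccc5oc4=O)cs3)cc(=O)[nH]c12`, 3.12%;
compound 3, `O=c1cc(CNc2nc(-c3cc4cc(Br)cc(Br)c4oc3=O)cs2)c2ccc(Cl)cc2[nH]1`, 3.27%.

In a functional assay on the whole organism for inhibition, with Rattus norvegicus as the target, read by paw edema, in the formalin test, with a stated time of 0.5 h, at a dose of 100 mg/kg by the intraperitoneal route (a higher number here means more inhibition at the dose given (going by the name of the read-out), a lower number less inhibition), compound 3 gives 3.27%, the second highest of the three numbers, yet one that lies within the scatter of compound 2 with 3.12% and of compound 1 with 6.75%. All three numbers sit close to the floor of the read-out.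

Compound 4, `O=c1cc(CNc2nc(-c3cc4cc(Br)ccc4oc3=O)cs2)c2ccc(Cl)cc2[nH]1`, is compound 3 with a single change: hydrogen in place of bromo on an aromatic carbon. Among the measured compounds shown here, no measured pair shows this change on its own. Since all three measured compounds give numbers within the scatter of one another, no step beyond the scatter is expected in this assay; the expected step of a number 0.7 percentage points higher from compound 3 to compound 4 (within the scatter) is small and without a clear direction. For compound 4 the estimate is 4%, with a range from 0% to 12%.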

Compound 4, a percentage reported as inhibition, in the whole organism at one dose (the size of the read-out at that dose, not a potency): 5.26%
Estimate against measurement, compound 4: 1.3 percentage points below; the range from low to high includes it.
By their numbers in this assay, from the lowest: compounds 2, 3, 4 and 1 (each within the scatter of the next).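

Hydrogen in place of bromo on an aromatic carbon, ortho to a fused ring, gives a number 2 percentage points higher from compound 3 to compound 4 (within the scatter) in this assay. Among the compounds shown here, this is the first direct reading of this position, and it shows that the bromo group there can be lost without the number leaving the scatter. Nothing at hand gives a reason for this step. On these data alone, whether an amine or a carboxylic acid on this carbon would move the number beyond the scatter stays open. So does whether this read-out at this dose can separate such compounds at all.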